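Methoxy to Chloro: An Expected Gain in Binding

The source may hold more compounds than are shown below. What is called first, only, known or untested is meant among the compounds shown, and "the series" means these compounds.

Compound 1 `Clc1ccc(C2=CC3CNCC(C2)C3)cn1` binds in an in vitro assay on SH-SY5Y cells for displacement of a labelled ligand from Neuronal acetylcholine receptor; alpha3/beta4 (Homo sapiens) (on this read-out lower numbers stand for stronger inhibition and higher numbers for weaker inhibition), giving 6.2 nM. Compound 2 `CN1CC2C=C(c3ccc(F)nc3)CC(C2)C1` gives 1310 nM in this assay. Compound 3 `COc1ccc(C2=CC3CC(C2)CN(C)C3)cn1` reaches only (the limit of > 10000 nM in this assay, at which 1 of the 3 values shown sits), so its reading of > 10000 nM is a limit of the assay rather than a number. Among the three readings, compound 3 therefore stands at the weak end. Within the data shown here, the one measured step that touches this position, an at least 7.6-fold higher number from compound 2 to compound 3 (0.88 log units; beyond the scatter), showed methoxy costing binding. Compound 4 `CN1CC2C=C(c3ccc(Cl)nc3)CC(C2)C1` carries chloro in place of methoxy on an aromatic carbon. Undoing a change of that kind should push the number downward, and the step expected for compound 4 is an at least 14-fold lower number from compound 3 to compound 4 (1.15 log units; beyond the scatter). The estimated value for compound 4 is 700 nM, with a range from 150 nM to 3000 nM.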

Compound 4, inhibition constant: 986 nM
Compound 4: the middle estimate sits 1.4-fold (0.15 log units) below what was measured; the measured number falls inside the stated range.
By their numbers in this assay, from the lowest: compound 1; then compounds 4 and 2 (each within the scatter of the next). At a limit, above all of these: compound 3.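

In this assay, chloro in place of methoxy next to the ring nitrogen gives an at least 10-fold lower number from compound 3 to compound 4 (1.00 log units; beyond the scatter). Chloro and fluoro are not told apart at this position, with a 1.3-fold lower number from compound 2 to compound 4 (0.12 log units; within the scatter), so among these three groups only methoxy stands out. A far larger difference comes from the other site: methyl in place of hydrogen on the amine nitrogen in the ring gives a 160-fold higher number from compound 1 to compound 4 (2.20 log units; beyond the scatter).

On these data alone, the true size of the methoxy loss stays open, as the reading for compound 3 is a limit and not a number: the limit of > 10000 nM in this assay, at which 1 of the 4 values shown sits. How an amine or a nitrile would read at this position also stays open.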